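Aryl exchange on the shared core: compound 3 next

The source may report more compounds than this note shows. Statements on the series, on what has been measured and on what is new or still open speak of the compounds shown alone.

Among the compounds with values here, in a functional assay on A549 cells (Homo sapiens) for inhibition, read by MTT assay, with a stated time of 24 h (on this read-out lower numbers stand for stronger inhibition and higher numbers for weaker inhibition), compound 1 `CC1(C)[C@H]2CC[C@]1(C)N(Cc1cn(-c3ccccc3Br)nn1)C(=O)C2` gives 130 nM and compound 2 `CC1(C)[C@H]2CC[C@]1(C)N(Cc1cn(-c3cccc(C#N)c3)nn1)C(=O)C2` gives 440 nM, the higher of the two numbers so far. Compound 3 `CC1(C)[C@H]2CC[C@]1(C)N(Cc1cn(-c3ccc(F)cc3)nn1)C(=O)C2` carries 4-fluorophenyl in place of 3-cyanophenyl on an aromatic nitrogen. Within the data shown here, the only measured step at this place is modest: a 3.4-fold higher number from compound 1 to compound 2 (0.53 log units; beyond the scatter). It sets a scale but involves a different group pair, so direction remains weakly defined. A small move is expected, with the estimated step being a 1.6-fold lower number from compound 2 to compound 3 (0.20 log units; within the scatter). For compound 3 the expected value is 280 nM, with an estimated range of 90 nM to 850 nM.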

Compound 3, half-maximal inhibitory concentration: 230 nM
Beside the measured number, compound 3's estimate is 1.2-fold (0.09 log units) above it; measured number inside the range.
By their numbers in this assay, from the lowest: compounds 1, 3 and 2 (each within the scatter of the next, the first and the last beyond it).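

In this assay, 4-fluorophenyl on the aromatic nitrogen cannot be ranked against 3-cyanophenyl (a 1.9-fold lower number from compound 2 to compound 3 (0.28 log units; within the scatter)) or against 2-bromophenyl (a 1.8-fold higher number from compound 1 to compound 3 (0.25 log units; within the scatter)), as both steps lie within the scatter. Only the two outer compounds of the set, compound 1 and compound 2, remain separated beyond it. No measurement on hand explains these numbers. The substituent and its place on the phenyl ring change together in all three compounds, so neither can be read alone. Also open, as far as these compounds go, is how a phenyl ring carrying an amine or a carboxylic acid, or a longer alkyl chain in place of the phenyl ring, would read here.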